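Chloro on a Chain-Bearing Compound at the Limit

A few compounds are considered here, and "the series" means these few. Any claim that something is new, unique, unknown or untested is made for them only; others in the source may bear on it.

Measured in an ADME assay on RAW264.7 cells (Mus musculus) for cytotoxicity, read by MTT assay (on this read-out lower numbers stand for stronger inhibition and higher numbers for weaker inhibition), with these results:
Compound 1 `CC(C)CCOc1cccc(O)c1C(=O)/C=C/c1ccc(O)cc1` gives > 30000 nM as a limit
Compound 2 `CCCCCCCCCCOc1cccc(O)c1C(=O)/C=C/c1ccc(O)cc1` gives > 30000 nM as a limit
Compound 3 `O=C(/C=C/c1ccc(O)cc1)c1c(O)cccc1OCc1ccccc1` gives > 30000 nM as a limit

Compound 2 has no number to stand on, only the limit shown. The whole set offers the same picture: the limit of > 30000 nM in this assay, at which 3 of the 3 values shown sit, and nothing more.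

Compound 4 `CCCCCCCCCCOc1cccc(O)c1C(=O)/C=C/c1ccc(O)c(Cl)c1` differs from compound 2 by a single change, chloro in place of hydrogen on an aromatic carbon and 4-hydroxyphenyl thereby becomes 3-chloro-4-hydroxyphenyl.

Three measured steps exist: a step that the two limits leave unreadable from compound 1 to compound 2 and a step that the two limits leave unreadable from compound 1 to compound 3 and also a step that the two limits leave unreadable from compound 2 to compound 3 in the same set. All three alter the chain, and none touches the 4-hydroxyphenyl group, so none gives a size for the chloro change.

The expectation rests on compound 2 alone, whose > 30000 nM is a limit, and it is for no step beyond the scatter in either direction. The estimated outcome is a number no higher from compound 2 to compound 4 (the limit leaves the size open) in this assay and another report of a limit is quite possible. For compound 4 the expected value is 30000 nM with an estimated range from 12000 nM to 80000 nM in this estimate.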

Compound 4, half-maximal inhibitory concentration: > 30000 nM
Compound 4: a limit, no number; the forecaster's own chance of this, stated with the estimate: 65%; the middle value lies on the limit itself.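

Compound 2 and compound 4 are both reported only as limits, so no step can be read for the chloro change between them. All the compounds shown end up in the same place: the limit of > 30000 nM in this assay, at which 4 of the 4 values shown sit.

The compounds shown leave open whether 3-chloro-4-hydroxyphenyl in place of 4-hydroxyphenyl shifts the value in this assay at all, and in which direction.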